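Adding a methoxy group to compound 3

The compounds below may be only part of what the source reports. "The series", "measured", "known", "first", "only" and "open" are said of these compounds alone.

Among the compounds with values here, in a functional assay on SW480 cells (Homo sapiens) for antiproliferative activity, read by sulforhodamine B assay, with a stated time of 48 h (on this read-out lower numbers stand for stronger inhibition and higher numbers for weaker inhibition), compound 3 (`COc1ccc(/C=C/C(=O)c2ccccc2-c2ccc(F)nc2)cc1`) gives 330 nM, the middle of the three numbers so far. Compound 2 (`COc1ccc(/C=C/C(=O)c2ccccc2-c2ccc(F)cc2)cc1`) gives 61 nM, and compound 1 (`COc1ccc(/C=C/C(=O)c2ccccc2-c2ccc(OC)c(OC)c2)cc1OC`) gives 7600 nM.

Compound 4 (`COc1ccc(/C=C/C(=O)c2ccccc2-c2ccc(F)nc2)cc1OC`) has methoxy in place of hydrogen on an aromatic carbon. Within the data shown here, the only measured single change, a 5.4-fold higher number from compound 2 to compound 3 (0.73 log units; beyond the scatter), lies at another place in the structure and does not test this methoxy group. Among the measured compounds shown here, compound 1 also holds this methoxy group but departs from compound 3 elsewhere, so it offers no clean step. The number of compound 1, 7600 nM, is therefore only a weak hint towards a higher number in this assay.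

A small rise is expected, possibly no larger than the scatter. The expected change is a 1.5-fold higher number from compound 3 to compound 4 (0.18 log units; within the scatter). For compound 4 the estimate is 500 nM, with an expected range from 130 nM to 2000 nM.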

Compound 4, half-maximal inhibitory concentration: 1300 nM
Beside the measured number, compound 4's estimate is 2.6-fold (0.41 log units) below it; measured number inside the range.
By their numbers in this assay, from the lowest: compound 2; then compound 3; then compound 4; then compound 1.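

Working notes on the methoxy position. In this assay, within the data shown here, methoxy in place of hydrogen on the aromatic carbon ortho to a methoxy group gives a 3.9-fold higher number from compound 3 to compound 4 (0.60 log units; beyond the scatter) and so provides the first clean reading at this position, a loss of activity beyond the scatter. With this methoxy group present in both compounds, 6-fluoropyridin-3-yl in place of 3,4-dimethoxyphenyl gives a 5.8-fold lower number from compound 1 to compound 4 (0.77 log units; beyond the scatter) and so the high number of compound 1 cannot be assigned to this methoxy group alone. No supporting data are available to explain either step.

On these data alone, it remains open whether the rise is particular to methoxy or would also follow from a hydroxyl group, an ethoxy group or an amine at this position. As far as these compounds go, it is also open whether the same methoxy step would hold with 4-fluorophenyl in place of 6-fluoropyridin-3-yl.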